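Three aryl ethers at the assay limit, and a difluoro analogue

The compounds below may be only part of what the source reports. "The series", "measured", "known", "first", "only" and "open" are said of these compounds alone.

Compound 1 `Cc1nnsc1CO/N=C/c1c(C)nn(C)c1Oc1cccc(C(F)(F)F)c1` in a functional assay on PANC-1 cells (Homo sapiens) for inhibition, read by MTT assay, with a stated time of 48 h (a lower number here means a stronger inhibitor, a higher number a weaker inhibitor), reaches only a limit, > 50000 nM.
Compound 2 `Cc1nnsc1CO/N=C/c1c(C)nn(C)c1Oc1ccc(F)cc1` in this assay reaches only a limit, > 50000 nM.
Compound 3 `Cc1nnsc1CO/N=C/c1c(C)nn(C)c1Oc1ccccc1OC(F)(F)F` in this assay reaches only a limit, > 50000 nM.

Compound 2 stands where every measured value here stands: at the limit of > 50000 nM in this assay, at which 3 of the 3 values shown sit, which is a limit and not a number. Among the measured compounds shown here, no step between two measured compounds is available, so the data do not show how exchanging the group on the oxygen of the shared core moves the read-out. Compound 4 `Cc1nnsc1CO/N=C/c1c(C)nn(C)c1Oc1cccc(F)c1F` carries 2,3-difluorophenyl in place of 4-fluorophenyl on an oxygen on an aromatic ring. Since compound 2 shows > 50000 nM, the expected step is a number no higher from compound 2 to compound 4 (the limit leaves the size open), none beyond the scatter, with the caveat that a limit gives no exact starting point. Compound 4 is therefore estimated at 50000 nM, within 20000 nM to 120000 nM, and most probably it too will be reported only as a limit.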

Compound 4, half-maximal inhibitory concentration: 12200 nM
Estimate against measurement, compound 4: 4.1-fold (0.61 log units) above; measured number outside the range, below it.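

Among the compounds shown here, compound 4 gives the first real number in this set, so in this assay the group on the oxygen of the shared core can move the read-out, with an at least 4.0-fold lower number from compound 2 to compound 4 (0.61 log units; beyond the scatter) when 2,3-difluorophenyl takes the place of 4-fluorophenyl. The true size of this step stays open because compound 2 gives a limit and not a number: the limit of > 50000 nM in this assay, at which 3 of the 4 values shown sit.

These compounds do not separate the effect of the second fluorine from the effect of where the fluorines sit. They also leave open how a phenyl ring carrying an amine or a carboxylic acid would behave.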